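A few compounds are considered here, and "the series" means these few. Any claim that something is new, unique, unknown or untested is made for them only; others in the source may bear on it.

Notes on the series. All compounds share one core carrying a variable group on an aromatic carbon. Compound 1 `Cc1nc2c3ccccc3ccc2c2nc3c(ccc4ccccc43)c(-c3cccnc3)c12` bears a pyridin-3-yl group there, compound 2 `Cc1nc2c3ccccc3ccc2c2nc3c(ccc4ccccc43)c(-c3nccnc3N)c12` a 3-aminopyrazin-2-yl group, and compound 3 `Cc1nc2c3ccccc3ccc2c2nc3c(ccc4ccccc43)c(-c3cc(O)nc4ccccc34)c12` a 2-hydroxyquinolin-4-yl group. In a functional assay on AGS cells (Homo sapiens) for cytotoxicity, read by MTT assay, with a stated time of 48 h (a higher number here means a weaker inhibitor, a lower number a stronger inhibitor), compound 1 gives 3960 nM. In this assay compound 2 gives 2260 nM. In this assay compound 3 gives 15800 nM, the highest of the three numbers, beyond the scatter from both others. The recorded steps are a 1.8-fold lower number from compound 1 to compound 2 (0.24 log units; within the scatter), a 4.0-fold higher number from compound 1 to compound 3 (0.60 log units; beyond the scatter) and a 7.0-fold higher number from compound 2 to compound 3 (0.84 log units; beyond the scatter).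

Compound 4 `Cc1nc2c3ccccc3ccc2c2nc3c(ccc4ccccc43)c(C)c12` is not yet measured. Its change from compound 3 is methyl in place of 2-hydroxyquinolin-4-yl on an aromatic carbon. Among the measured compounds shown here, the steps that bear on it are a 4.0-fold higher number from compound 1 to compound 3 (0.60 log units; beyond the scatter) and a 7.0-fold higher number from compound 2 to compound 3 (0.84 log units; beyond the scatter): each exchanges the group on this carbon, and in each the 2-hydroxyquinolin-4-yl group carried the higher number. For the measured compounds named here, no measured step replaces an aromatic group at this carbon by methyl, so the size of the coming step is uncertain and the range must be wide. A lower number is expected for compound 4, a step of about a 3.2-fold lower number from compound 3 to compound 4 (0.50 log units; beyond the scatter). Compound 4 is estimated at 5000 nM in this assay, with a range of 1500 nM to 20000 nM.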

Compound 4, half-maximal inhibitory concentration: > 80000 nM
Compound 4 was reported as a limit; the forecaster's own chance of this, stated with the estimate: 10%; middle value at least 16-fold (1.20 log units) from the limit.
By their numbers in this assay, from the lowest: compounds 2 and 1 (each within the scatter of the next); then compound 3. At a limit, above all of these: compound 4.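

In this assay compound 4 gives a limit and not a number: the limit of > 80000 nM in this assay, at which 1 of the 4 values shown sits. Replacing an aromatic group at this carbon by methyl is a larger change than any exchange among the aromatic groups, and even the group with the highest earlier number does not mark the end of the range, with an at least 5.0-fold higher number from compound 3 to compound 4 (0.70 log units; beyond the scatter), while the two remaining exchanges give an at least 35-fold higher number from compound 2 to compound 4 (1.54 log units; beyond the scatter) and an at least 20-fold higher number from compound 1 to compound 4 (1.30 log units; beyond the scatter). Across these four compounds, each of the three ring-bearing groups gives a number in this assay and methyl alone gives only a limit, so the position is shown to matter far more than the earlier exchanges among ring-bearing groups could reveal.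

The compounds shown leave open whether a ring at this carbon is what counts, since an amine, a carboxylic acid or a longer chain in the same place could separate the presence of a ring from the mere presence of a group larger than methyl. Going by these compounds, the true value of compound 4 also remains unknown, so its three steps have a floor but no upper end.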